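Oxadiazole aryl replacement: cytotoxicity working notes

This account rests on a few compounds, and the source may have more. Where it says the series, first, only, none or still open, it means among the compounds named here.

Compound 1 `COc1nc2ccccc2cc1/C=C/c1noc(-c2ccc(Br)cc2)n1`: > 195000 nM
Compound 2 `COc1nc2ccccc2cc1/C=C/c1noc(-c2cccc(C)c2)n1`: > 230000 nM

In an ADME assay on HepG2 cells (Homo sapiens) for cytotoxicity, read by sulforhodamine B assay, with a stated time of 48 h (a higher number here means that more compound is tolerated, a lower number that less compound is tolerated), compound 1 returns only a limit, > 195000 nM. Compound 2 likewise returns only a limit, > 230000 nM. The step that the two limits leave unreadable from compound 1 to compound 2 therefore cannot be read, since both values sit at limits (the limit of > 195000 nM in this assay, at which 1 of the 2 values shown sits, (the limit of > 230000 nM in this assay, at which 1 of the 2 values shown sits)). Going by the values given here, compound 2 thus stands at a limit, and the one further value shown is also a limit; no numbered value exists.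

Compound 3 `COc1nc2ccccc2cc1/C=C/c1noc(COc2ccccc2)n1` differs from compound 2 by phenoxymethyl in place of 3-methylphenyl on an aromatic carbon. Among the compounds with values here, no measured step bears on this change as a readable number, so its size in this assay is not fixed by what has been measured. With compound 2 at a limit, compound 3 is expected to remain near that limit, estimated at 200000 nM with a range of 60000 nM to 300000 nM. The expected step of an at least 1.1-fold lower number from compound 2 to compound 3 (0.06 log units; that floor lies within the scatter) is accordingly none beyond the scatter, most likely reported again as a limit.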

Compound 3, half-maximal cytotoxic concentration: > 220000 nM
Compound 3 ended at the assay's limit; the forecaster's own chance of this, stated with the estimate: 75%; middle value at least 1.1-fold (0.04 log units) away from the limit.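

Compound 3 returns only a limit in this assay: the limit of > 220000 nM in this assay, at which 1 of the 3 values shown sits.

Going by these compounds alone, no step among compound 1, compound 2 and compound 3 can be read, since all three values are limits. Still open, going by these compounds, is whether 4-bromophenyl, 3-methylphenyl and phenoxymethyl differ at all in this assay.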